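A carbamate in place of the thiocarbamate at the ring carbon

This account rests on a few compounds, and the source may have more. Where it says the series, first, only, none or still open, it means among the compounds named here.

Of the compounds shown here, two on one shared core have been measured in an assay on cell membranes for displacement of a labelled ligand from proteinase-activated receptor 1 (Homo sapiens), read by scintillation counting, with a stated time of 60 min; a lower number here means a stronger inhibitor, a higher number a weaker inhibitor. Compound 1 `COC1C[C@@H]2CCCC[C@@H]2[C@H]1/C=C/c1ccc(-c2cccc(F)c2)cn1` gives 67 nM, and compound 2 `CN(C)C(=S)OC1C[C@@H]2CCCC[C@@H]2[C@H]1/C=C/c1ccc(-c2cccc(F)c2)cn1` gives 120 nM. On the numbers as they stand, compound 2 has the higher of the two, but the step of a 1.8-fold higher number from compound 1 to compound 2 (0.25 log units; within the scatter) lies within the scatter, so the two compounds are not distinguished by this assay.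

Compound 3 `COC(=O)NC1C[C@@H]2CCCC[C@@H]2[C@H]1/C=C/c1ccc(-c2cccc(F)c2)cn1` has not been measured. It differs from compound 2 in this way: a group of 5 heavy atoms (2 carbon, 1 nitrogen, 2 oxygen; no ring) in place of a group of 6 heavy atoms (3 carbon, 1 nitrogen, 1 oxygen, 1 sulfur; no ring), on a saturated ring carbon. For the measured compounds named here, only one measured step exists, the one from compound 1 to compound 2, which exchanged a one-carbon group on the oxygen for the thiocarbamate and stayed within the scatter. Going by the values given here, no measured step touches a (methoxycarbonyl)amino group or a nitrogen on this ring carbon, so nothing bears directly on the change into compound 3. Given that the one known change at this position moved the number by so little, the expected step is a 1.2-fold lower number from compound 2 to compound 3 (0.08 log units; within the scatter), with no change beyond the scatter. Compound 3 is therefore estimated at 100 nM, with a range from 35 nM to 300 nM.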

Compound 3, half-maximal inhibitory concentration: 980 nM
Beside the measured number, compound 3's estimate is 9.8-fold (0.99 log units) below it; measured number outside the range, above it.
By their numbers in this assay, from the lowest: compounds 1 and 2 (each within the scatter of the next); then compound 3.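

In this assay, this saturated ring carbon turns out to be sensitive to what it carries: the earlier exchange on the oxygen gave only a 1.8-fold higher number from compound 1 to compound 2 (0.25 log units; within the scatter), whereas the change to the (methoxycarbonyl)amino group gives an 8.2-fold higher number from compound 2 to compound 3 (0.91 log units; beyond the scatter), which lies beyond the scatter. The same group in place of methoxy gives a 15-fold higher number from compound 1 to compound 3 (1.17 log units; beyond the scatter), a large step, so compound 3 stands apart from both earlier compounds, which themselves remain undistinguished. Compound 3 also holds a hydrogen-bond donor in this group, which the group leaving compound 2 lacks, but nothing available explains the loss or ties it to that difference.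

What the compounds shown leave open is whether the higher number follows the nitrogen on the ring carbon, the carbonyl attached to it, or the two together, since these enter at once in compound 3. A free amine, an N-methyl carbamate or a simple hydroxyl group at this position would help separate those possibilities, and the stereochemistry at this ring carbon also remains unresolved.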